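The source may report more compounds than this note shows. Statements on the series, on what has been measured and on what is new or still open speak of the compounds shown alone.

Compound 1 `COc1ccc(C(=O)CCC(=O)NCCCO)cc1` belongs to a small set of open-chain ketoamides carrying a hydroxypropyl amide, assessed in a functional assay on the whole organism with Mus musculus as the target; a lower number here means that less compound is needed, a higher number that more compound is needed for the effect. In this assay compound 1 gives only a limit, > 600 mg/kg, and no number. Its thiophene analogue, compound 2 `O=C(CCC(=O)c1cccs1)NCCCO`, likewise gives only a limit in this assay, > 300 mg/kg. Among the compounds with values here, the one member of the set with a measured number is the ring-closed compound 3 `O=C1CCCC2(c3ccccc3)OCCCN12`, which in this assay gives 122 mg/kg. Compound 1 therefore stands at one of the two limits among the three values shown, described by the limit of > 600 mg/kg in this assay, at which 1 of the 3 values shown sits, while compound 2 sits at the other, (the limit of > 300 mg/kg in this assay, at which 1 of the 3 values shown sits); no measured step between any two of these compounds can be drawn.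

The next compound, compound 4 `Cc1ccc(C(=O)CCC(=O)NCCCO)cc1`, differs from compound 1 in one place only: methyl in place of methoxy on an aromatic carbon. With compound 1 recorded as a limit rather than a number, no step size can be read from the measured values themselves, and nothing in the set shows how this change affects this assay. Compound 4 is therefore expected to sit close to where compound 1 stands, with the step from an at least 1.2-fold lower number from compound 1 to compound 4 (0.07 log units; that floor lies within the scatter) estimated as small or none beyond the usual scatter. Compound 4 is estimated at 500 mg/kg in this assay, within a range of 150 mg/kg to 2000 mg/kg, and there is a real chance that it too will give only a limit.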

Compound 4, dose for half-maximal effect: > 300 mg/kg
Compound 4: no number, only a limit; the forecaster's own chance of this, stated with the estimate: 65%; the middle value does not contradict the limit.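

In this assay, within the data shown here, compound 4 gives only a limit, > 300 mg/kg, and compound 1 is likewise recorded only as a limit, so no step between compound 1 and compound 4 can be read. The compounds shown leave open whether methyl in place of methoxy changes the dose needed for the effect at all.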